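From 2,3-Dichlorophenyl to 3,5-Dichlorophenyl

This account rests on a few compounds, and the source may have more. Where it says the series, first, only, none or still open, it means among the compounds named here.

In a functional assay on HCT-116 cells (Homo sapiens) for antiproliferative activity, read by sulforhodamine B assay, with a stated time of 48 h (on this read-out higher numbers stand for weaker inhibition and lower numbers for stronger inhibition), compound 1 `COc1cc(O)c(C(=O)/C=C/c2cccc(Cl)c2Cl)c(OC)c1` reads 2700 nM while compound 2 `COc1cccc(/C=C/C(=O)c2c(O)cc(OC)cc2OC)c1` reads 3100 nM and compound 3 `COc1cc(OC)c(C(=O)/C=C/c2cccc(Cl)c2Cl)c(OCC=C(C)C)c1` reads 1900 nM and so sits within the scatter of both others, which leaves it not separable from them on these numbers. Among the measured compounds shown here, the one measured step reaching compound 3 is a 1.4-fold lower number from compound 1 to compound 3 (0.15 log units; within the scatter) for 3-methylbut-2-en-1-yl in place of hydrogen on an oxygen on an aromatic ring, and that step lies elsewhere in the structure. For the measured compounds named here, compound 4 `COc1cc(OC)c(C(=O)/C=C/c2cc(Cl)cc(Cl)c2)c(OCC=C(C)C)c1` keeps this group and differs from compound 3 as 3,5-dichlorophenyl in place of 2,3-dichlorophenyl on a double-bonded chain carbon bound to a double-bonded chain carbon and no measured pair isolates that exchange. The closest indirect evidence is that compound 1 at 2700 nM and compound 2 at 3100 nM lie close together although their groups at that place differ. No direction can therefore be argued, and the expected step is a 1.1-fold higher number from compound 3 to compound 4 (0.02 log units; within the scatter) with nothing beyond the scatter anticipated. Compound 4 is estimated at 2000 nM with an expected range from 800 nM to 5000 nM in this assay once it is measured.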

Compound 4, half-maximal inhibitory concentration: 24500 nM
Estimate against measurement, compound 4: 12-fold (1.09 log units) below; measured number outside the range, above it.
By their numbers in this assay, from the lowest: compounds 3, 1 and 2 (each within the scatter of the next); then compound 4.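

In this assay, 3,5-dichlorophenyl in place of 2,3-dichlorophenyl on a double-bonded chain carbon bound to a double-bonded chain carbon gives a 13-fold higher number from compound 3 to compound 4 (1.11 log units; beyond the scatter), so the activity at this place depends strongly on how the two chlorines are arranged, even though the groups have the same atoms. The earlier compounds shown here gave no sign of this: compound 1 at 2700 nM and compound 2 at 3100 nM carry different groups at this place, yet stand within the scatter of each other. Nothing shown here accounts for the size of this step.

From the compounds shown here alone, it remains open whether 3,5-dichlorophenyl would cost as much in a compound with hydrogen in place of 3-methylbut-2-en-1-yl on the oxygen. Going by these compounds, how a phenyl group bearing a single chlorine or an amine would read at this place also remains open.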